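The compounds below may be only part of what the source reports. "The series", "measured", "known", "first", "only" and "open" are said of these compounds alone.

Compound 2, `Cc1cc(C)cc(S(=O)(=O)c2c(C(=O)NCCOc3ccccc3)[nH]c3ccc(Br)cc23)c1`, is the measured compound closest to the unmeasured one. In an ADME assay on CCRF-CEM cells (Homo sapiens) for cytotoxicity, read by cell counting (a lower number here means that less compound is tolerated, a higher number that more compound is tolerated), compound 2 reaches only a limit, > 500000 nM. Its partner compound 1, `Cc1cc(C)cc(S(=O)(=O)c2c(C(=O)NCCOc3ccccc3)[nH]c3ccc(Cl)cc23)c1`, gives 207000 nM in this assay, so the step of an at least 2.4-fold higher number from compound 1 to compound 2 (0.38 log units; beyond the scatter) is known only as a bound because one of the values sits at the limit of > 500000 nM in this assay, at which 1 of the 2 values shown sits. Compound 3, `Cc1cc(C)cc(S(=O)(=O)c2c(C(=O)NCCOc3ccccc3)[nH]c3ccc([N+](=O)[O-])cc23)c1`, differs from compound 2 by nitro in place of bromo on an aromatic carbon. Within the data shown here, no measured step exchanges a halogen for a nitro group; the one step available swaps one halogen for another and moved the number upward to the limit. Both measured values lie in a region of very high tolerated concentration. Compound 3 is therefore expected to stay in that region, with only a modest estimated step of an at least 1.4-fold lower number from compound 2 to compound 3 (0.15 log units; that floor lies within the scatter). Compound 3 is estimated at 350000 nM, in a range from 120000 nM to 1000000 nM.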

Compound 3, half-maximal cytotoxic concentration: > 500000 nM
Compound 3: no number, only a limit; the forecaster's own chance of this, stated with the estimate: 45%; middle value at least 1.4-fold (0.15 log units) from the limit.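

In this assay compound 3 gives > 500000 nM, which is a limit and not a number. Nitro in place of chloro gives an at least 2.4-fold higher number from compound 1 to compound 3 (0.38 log units; beyond the scatter), so a group that is no halogen also carries this position past the value of compound 1, and chloro remains the only one of the three groups shown that yields a readable number. The step between compound 2 and compound 3 cannot be read because both compounds sit at the same limit: the limit of > 500000 nM in this assay, at which 2 of the 3 values shown sit.

On these data alone, whether bromo and nitro differ at this position therefore stays open, as does how far either lies beyond the limit. Also open, as far as these compounds go, is where an amine, a carboxylic acid or a fluoro group at this position would fall relative to compound 1.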